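Moving the ring nitrogen: from compound 3 to compound 4

This account rests on a few compounds, and the source may have more. Where it says the series, first, only, none or still open, it means among the compounds named here.

Measured in an assay on CHO cells for displacement of a labelled ligand from transient receptor potential cation channel subfamily V member 1 (Homo sapiens), read by scintillation counting, with a stated time of 60 min; a higher number here means a weaker inhibitor, a lower number a stronger inhibitor:
Compound 1, `CN(C)C1(Cc2ccccc2)CCN(c2cc(C(F)(F)F)ccc2CNC(=O)Nc2ccc(NS(C)(=O)=O)c(F)c2)CC1`: 1160 nM
Compound 2, `CN(C)C1(Cc2ccccc2)CCN(c2cc(C(F)(F)F)ccc2CNC(=O)Nc2cccc3c(=O)[nH]ccc23)CC1`: 111 nM
Compound 3, `CN(C)C1(Cc2ccccc2)CCN(c2cc(C(F)(F)F)ccc2CNC(=O)Nc2ccc3ccncc3c2)CC1`: 7.33 nM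

Compound 3 has the lowest number of the three, and so is the strongest inhibitor here: the step of a 15-fold lower number from compound 2 to compound 3 (1.18 log units; beyond the scatter) and the step of a 160-fold lower number from compound 1 to compound 3 (2.20 log units; beyond the scatter) both lie beyond the scatter. The step of a 10-fold lower number from compound 1 to compound 2 (1.02 log units; beyond the scatter) was large as well. All three steps replace the whole aryl group on the urea nitrogen, and each moved the number a lot.

Compound 4, `CN(C)C1(Cc2ccccc2)CCN(c2cc(C(F)(F)F)ccc2CNC(=O)Nc2cccc3ccncc23)CC1`, makes a smaller change: isoquinolin-8-yl in place of isoquinolin-7-yl on an amide-type nitrogen. Within the data shown here, no measured step moves only the point at which the same ring system is attached, so the three large steps show only that this part of the molecule is sensitive, not how far a shift within the ring system will go. The expected outcome is a step toward a higher number, a 3.4-fold higher number from compound 3 to compound 4 (0.53 log units; beyond the scatter), of moderate size. Compound 4 is therefore estimated at 25 nM, with a range from 4 nM to 150 nM.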

Compound 4, inhibition constant: 12.3 nM
Compound 4: middle estimate off by 2.0-fold (0.31 log units), on the high side; low and high end bracket the measured number.
By their numbers in this assay, from the lowest: compounds 3 and 4 (each within the scatter of the next); then compound 2; then compound 1.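

Swapping isoquinolin-7-yl for isoquinolin-8-yl on the amide-type nitrogen gives a 1.7-fold higher number from compound 3 to compound 4 (0.22 log units; within the scatter), so this shift of the attachment point, unlike the whole-group replacements seen earlier, does not separate the two compounds. Isoquinolin-8-yl also stays clearly apart from the other two aryl groups on that nitrogen, with a 9.0-fold lower number from compound 2 to compound 4 (0.96 log units; beyond the scatter) and a 94-fold lower number from compound 1 to compound 4 (1.97 log units; beyond the scatter). Nothing available here offers an explanation for these numbers.

From the compounds shown here alone, whether the ring nitrogen matters at all remains open, and naphthalen-2-yl, the same pair of rings with carbon in place of that nitrogen, would test it. Also open, going by these compounds, is how other attachment points, such as isoquinolin-5-yl or isoquinolin-6-yl, would read, and what an added amine or methoxy group on the ring would do to the number.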